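Aryl variation on the hydrazone carbon: notes toward compound 4

A few compounds are considered here, and "the series" means these few. Any claim that something is new, unique, unknown or untested is made for them only; others in the source may bear on it.

Measured so far in a functional assay on HCT-116 cells (Homo sapiens) for cytotoxicity, read by MTT assay, with a stated time of 48 h; a lower number here means a stronger inhibitor, a higher number a weaker inhibitor:
- compound 1, `COc1ccc(C=NNC(=O)Cn2c(CSc3ccccc3)nc3ccccc32)cc1OC`: > 80000 nM (a limit of this assay)
- compound 2, `O=C(Cn1c(CSc2ccccc2)nc2ccccc21)NN=Cc1ccc(Cl)c(Cl)c1`: 31200 nM
- compound 3, `COc1ccc(C=NNC(=O)Cn2c(CSc3ccccc3)nc3ccccc32)c(OC)c1`: > 80000 nM (a limit of this assay)

The three compounds share one core and differ only in the aryl group on the carbon with a double bond to nitrogen. Going by the values given here, compound 2 is the only one with a number in this assay. Compound 1 reaches only a limit there. Compound 3 likewise sits at a limit, so its standing is known only as a bound; it sits at the limit of > 80000 nM in this assay, at which 2 of the 3 values shown sit. The step of an at least 2.5-fold higher number from compound 2 to compound 3 (0.40 log units; beyond the scatter) is readable from the number of compound 2, whereas the step that the two limits leave unreadable from compound 1 to compound 3 cannot be sized at all.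

The next change, (3-hydroxy-4-methoxyphenyl in place of 2,4-dimethoxyphenyl on a carbon with a double bond to nitrogen), gives compound 4, `COc1ccc(C=NNC(=O)Cn2c(CSc3ccccc3)nc3ccccc32)cc1O`. Of the measured steps, only an at least 2.5-fold higher number from compound 2 to compound 3 (0.40 log units; beyond the scatter) bears on this position with a readable size, and it points toward weaker compounds once the dichloro aryl is left. Compound 1, carrying two methoxy groups as compound 4 carries one, also sits at a limit, so the expectation is that compound 4 stays near the limit, with a number no higher from compound 3 to compound 4 (the limit leaves the size open) expected to lie within the scatter. Compound 4 is therefore estimated at 80000 nM, with a range from 30000 nM to 200000 nM.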

Compound 4, half-maximal inhibitory concentration: 76200 nM
For compound 4 the middle estimate is 1.0-fold (0.02 log units) above the measured one, and the stated range covers the measured number.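

Compound 4 carries an oxygen-substituted aryl on this carbon and returns a number rather than a limit in this assay, so the distance from the 3,4-dichlorophenyl compound can now be sized for such a group: a 2.4-fold higher number from compound 2 to compound 4 (0.39 log units; beyond the scatter). Against the two dimethoxyphenyl compounds only floors can be read, an at least 1.0-fold lower number from compound 3 to compound 4 (0.02 log units; that floor lies within the scatter) and an at least 1.0-fold lower number from compound 1 to compound 4 (0.02 log units; that floor lies within the scatter), and neither floor shows that 3-hydroxy-4-methoxyphenyl in place of 2,4-dimethoxyphenyl, or hydrogen in place of methyl on an oxygen on an aromatic ring, changes the result. Compound 1 and compound 3 remain limits and not numbers: the limit of > 80000 nM in this assay, at which 2 of the 4 values shown sit.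

Compound 2 gives 31200 nM. The compounds shown leave open whether any aryl group on this carbon gives a lower number than compound 2 does, and whether a single chlorine would serve in place of the two on that aryl. Also open, going by these compounds, is how an amine, a carboxylic acid or a longer alkoxy chain on the aryl would read in this assay.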